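Antiproliferative series: swapping the aryl arm of compound 1

A few compounds are considered here, and "the series" means these few. Any claim that something is new, unique, unknown or untested is made for them only; others in the source may bear on it.

compound 1 `COc1ccc(C(=O)/C=C/c2ccc(N(C)C)cc2)c2c1C=CC(C)(C)O2` — 570 nM
compound 2 `COc1ccc(C(=O)/C=C/c2ccc3ccccc3n2)c2c1C=CC(C)(C)O2` — 2250 nM

In a functional assay on SW-620 cells (Homo sapiens) for antiproliferative activity, read by MTT assay, with a stated time of 24 h (a lower number here means a stronger inhibitor, a higher number a weaker inhibitor), compound 1 gives 570 nM, the lower of the two numbers seen so far. Compound 2 gives 2250 nM, a gap beyond the scatter.

Compound 3 `COc1ccc(C(=O)/C=C/c2ccccc2Cl)c2c1C=CC(C)(C)O2` differs from compound 1 by 2-chlorophenyl in place of 4-(dimethylamino)phenyl on a double-bonded chain carbon bound to a double-bonded chain carbon. Among the compounds with values here, no measured pair covers this exchange, so the expectation rests only on compound 1 and the weaker compound 2. A moderate upward step in this assay, beyond the scatter, is expected; the expected step is a 2.6-fold higher number from compound 1 to compound 3 (0.42 log units; beyond the scatter). Compound 3 is estimated at 1500 nM, with a range from 500 nM to 5000 nM.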

Compound 3, half-maximal inhibitory concentration: > 10000 nM
Compound 3 was reported as a limit; the forecaster's own chance of this, stated with the estimate: 5%; middle value at least 6.6-fold (0.82 log units) from the limit.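

Exchanging 4-(dimethylamino)phenyl for 2-chlorophenyl on a double-bonded chain carbon bound to a double-bonded chain carbon gives an at least 17-fold higher number from compound 1 to compound 3 (1.24 log units; beyond the scatter) in this assay. With the shared core unchanged, this place alone separates the two compounds, and the aryl arm there is far from interchangeable. The value for compound 3 is a limit, not a number: the limit of > 10000 nM in this assay, at which 1 of the 3 values shown sits.

From the compounds shown here alone, whether the loss follows from removing the dimethylamino group or from introducing the chlorine stays open, since both change together. An unsubstituted phenyl arm at this place would help separate the two.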